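Cyano in place of methyl on a selenium: compound 4

The source may report more compounds than this note shows. Statements on the series, on what has been measured and on what is new or still open speak of the compounds shown alone.

Measured in a functional assay on A549 cells (Homo sapiens) for inhibition, read by MTT assay, with a stated time of 48 h; a higher number here means a weaker inhibitor, a lower number a stronger inhibitor:
compound 1, `COc1ccc(N(C)c2nc(C)nc3ccccc23)cc1C(=O)NCC[Se]C#N`, gives 187 nM
compound 2, `COc1ccc(N(C)c2nc(C)nc3ccccc23)cc1C(=O)OCCC[Se]C#N`, gives 250 nM
compound 3, `C[Se]c1ccc(N(C)c2nc(C3CC3)nc3ccccc23)cc1`, gives 13 nM

Compound 3 holds the lowest number of the three in this assay ; compound 1 is its nearest neighbour and compound 2 the furthest, both beyond the scatter. Among the measured compounds shown here, the one step between measured compounds that differ in one place, a 1.3-fold higher number from compound 1 to compound 2 (0.13 log units; within the scatter), concerns a change on a carbonyl carbon and does not touch the selenium.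

Compound 4, `CN(c1ccc([Se]C#N)cc1)c1nc(C2CC2)nc2ccccc12`, differs from compound 3 in one place: cyano in place of methyl on a selenium. For the measured compounds named here, no measured step bears directly on this change. Compounds 1 and 2 carry the cyano on their selenium and stand well above compound 3, but they differ from compound 3 in several other places as well, so their values show only that a cyano on selenium is compatible with measurable inhibition in this assay . The step to compound 4 is expected to be modest and to give a somewhat higher number, a 3.1-fold higher number from compound 3 to compound 4 (0.49 log units; beyond the scatter), with wide uncertainty.

Compound 4 is therefore expected to give 40 nM in this assay , within a range from 10 nM to 160 nM.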

Compound 4, half-maximal inhibitory concentration: 12 nM
Compound 4: middle estimate off by 3.3-fold (0.52 log units), on the high side; the measured number falls inside the stated range.
By their numbers in this assay, from the lowest: compounds 4 and 3 (each within the scatter of the next); then compounds 1 and 2 (each within the scatter of the next).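

On a selenium whose other neighbour is an aromatic carbon, the change of methyl to cyano can now be read directly: in this assay there is a 1.1-fold lower number from compound 3 to compound 4 (0.03 log units; within the scatter). Compound 3 and compound 4 therefore cannot be told apart, and at this place, with this core, the cyano on selenium carries no measurable cost or gain relative to the methyl. Nothing on hand offers a reason for this equivalence.

As far as these compounds go, it remains open whether a longer chain such as ethyl or propyl on the selenium, or sulfur in place of the selenium, would also leave the number unchanged. Among the compounds shown here, no single-place step links compound 3 or compound 4 to compound 1 or compound 2, so the gap between these pairs cannot be assigned to any one structural difference.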